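Swapping ethylamino for dimethylamino on the shared core

This account rests on a few compounds, and the source may have more. Where it says the series, first, only, none or still open, it means among the compounds named here.

Measured so far:
compound 1, `CCNc1nc(NCc2ccc(NC(=O)c3ccc(F)cc3)cc2)c2ccccc2n1`: 2300 nM
compound 2, `CCNc1nc(NCc2ccc(C(=O)N[C@H]3C[C@@H]3c3ccccc3)cc2)c2cc(C)ccc2n1`: 1800 nM
compound 3, `Cc1ccc2nc(N(C)C)nc(NCc3ccc(C(=O)NC4CCN(Cc5ccc(F)cc5)CC4)cc3)c2c1`: 1100 nM

In a functional assay on SW480 cells (Homo sapiens) for inhibition, read by luminescence and resazurin assay, with a stated time of 3 days (a lower number here means a stronger inhibitor, a higher number a weaker inhibitor), compound 2 gives 1800 nM, and it sits second highest of the three numbers; its gaps to compound 1 and to compound 3 both fall within the usual scatter, so the three values cannot be ordered.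

Compound 4, `Cc1ccc2nc(N(C)C)nc(NCc3ccc(C(=O)N[C@H]4C[C@@H]4c4ccccc4)cc3)c2c1`, is the unmeasured partner of compound 2. Within the data shown here, the single change is dimethylamino in place of ethylamino on an aromatic carbon. Among the measured compounds shown here, no pair of measured compounds isolates this change, so no step can be read off. Compound 3 carries the dimethylamino group and gives 1100 nM, close to compound 2.

Compound 4 is therefore expected to stay within the scatter of compound 2, with an estimated step of a 1.2-fold lower number from compound 2 to compound 4 (0.08 log units; within the scatter) and an estimated value of 1500 nM, between 500 nM and 4500 nM.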

Compound 4, half-maximal inhibitory concentration: 2400 nM
Estimate against measurement, compound 4: 1.6-fold (0.20 log units) below; the measured number falls inside the stated range.
By their numbers in this assay, from the lowest: compounds 3, 2, 1 and 4 (each within the scatter of the next, the first and the last beyond it).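

Among these compounds, this is the first pair in this assay to isolate this change at this position: dimethylamino in place of ethylamino gives a 1.3-fold higher number from compound 2 to compound 4 (0.12 log units; within the scatter) and leaves the two compounds within the scatter of each other. The hydrogen-bond donor of ethylamino is absent from dimethylamino, yet in this one pair that difference produces no step beyond the scatter. Nothing measured here explains the result.

On these data alone, whether a ring amine such as pyrrolidine or morpholine, or a methoxy group, would fare the same on this carbon stays open. So does whether the change would give a similar step with a different amide side chain.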